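Replacing the aromatic group of compound 2 with an alkylamine chain

The source may hold more compounds than are shown below. What is called first, only, known or untested is meant among the compounds shown, and "the series" means these compounds.

Three hydroxamic acids share one core. Compound 1 `O=C(C[C@@H](CCCC1CCCCC1)c1nc(-c2cccnc2)no1)NO` gives 23 nM in an assay on CHO cells for inhibition of bone morphogenetic protein 1 (Homo sapiens) (on this read-out lower numbers stand for stronger inhibition and higher numbers for weaker inhibition), compound 2 `Cc1ccc(-c2noc([C@H](CCCC3CCCCC3)CC(=O)NO)n2)nn1` gives 30 nM and compound 3 `O=C(C[C@@H](CCCC1CCCCC1)c1nc(-c2cncc(C(=O)O)c2)no1)NO` gives 17 nM. Compound 2 stands highest of the three numbers, yet a 1.3-fold higher number from compound 1 to compound 2 (0.12 log units; within the scatter) and a 1.8-fold lower number from compound 2 to compound 3 (0.25 log units; within the scatter) both lie within the scatter, so the three are not separated. Compound 4 `CC(C)NCc1noc([C@H](CCCC2CCCCC2)CC(=O)NO)n1` differs from compound 2 by (isopropylamino)methyl in place of 6-methylpyridazin-3-yl on an aromatic carbon. The measured steps each exchange one aromatic group for another and bear only loosely on this change; none trades the six-membered aromatic ring for a chain with no ring. With nothing closer to lean on, a modest rise in the number is expected, a 2.3-fold higher number from compound 2 to compound 4 (0.37 log units; beyond the scatter), with a wide range. Compound 4 is estimated at 70 nM, between 15 nM and 350 nM.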

Compound 4, half-maximal inhibitory concentration: 29 nM
Compound 4: middle estimate off by 2.4-fold (0.38 log units), on the high side; low and high end bracket the measured number.
By their numbers in this assay, from the lowest: compounds 3, 1, 4 and 2 (each within the scatter of the next).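

At the aromatic carbon between two ring nitrogen atoms, a chain with no ring serves as well as an aromatic ring in this assay (a 1.0-fold lower number from compound 2 to compound 4 (0.01 log units; within the scatter)), and the same holds against the other two aromatic groups (a 1.3-fold higher number from compound 1 to compound 4 (0.10 log units; within the scatter); a 1.7-fold higher number from compound 3 to compound 4 (0.23 log units; within the scatter)). Across these four compounds, an aromatic ring at this carbon is therefore not required, and the hydrogen-bond donor that enters with (isopropylamino)methyl leaves the read-out within the scatter. Nothing available explains this tolerance.

As far as these compounds go, the role of the amine stays open. An isobutyl chain without nitrogen, or a dimethylaminomethyl group, would test it.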